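Swapping one aromatic group for another in a lung-cell tolerance test

The compounds below may be only part of what the source reports. "The series", "measured", "known", "first", "only" and "open" are said of these compounds alone.

Measured compounds, with their values in an ADME assay on A549 cells (Homo sapiens) for cytotoxicity, read by CellTiter-Glo; a lower number here means that less compound is tolerated, a higher number that more compound is tolerated:
compound 1 `Cc1c(Cc2ccc(F)cc2)c(=O)oc2cc(OCC(O)CN3CCC(C(N)=O)CC3)ccc12` — 89300 nM
compound 2 `Cc1c(Cc2cccc3ccccc23)c(=O)oc2cc(OCC(O)CN3CCC(C(N)=O)CC3)ccc12` — 42400 nM

For the measured compounds named here, compound 2 holds the lower of the two numbers, and compound 1 stands above it; the only comparison in hand is a 2.1-fold lower number from compound 1 to compound 2 (0.32 log units; beyond the scatter). Compound 3 `Cc1c(Cc2ccc(-c3ccccc3)cc2)c(=O)oc2cc(OCC(O)CN3CCC(C(N)=O)CC3)ccc12` has not yet been tested in this assay. It differs from compound 2 in a single place: 4-phenylphenyl in place of naphthalen-1-yl on a saturated chain carbon bound to an aromatic carbon. Going by the values given here, the one measured step that bears on this change is a 2.1-fold lower number from compound 1 to compound 2 (0.32 log units; beyond the scatter), which exchanged one aromatic group for another at the same place and brought a modest lowering. The new exchange is of like kind, an aromatic group giving way to another aromatic group, so a small step is expected, most likely a slight further lowering and possibly none beyond the scatter: a 1.2-fold lower number from compound 2 to compound 3 (0.08 log units; within the scatter). Compound 3 is therefore estimated at 35000 nM, with a range from 15000 nM to 80000 nM.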

Compound 3, half-maximal cytotoxic concentration: > 100000 nM
Compound 3 gave a limit, no number; the forecaster's own chance of this, stated with the estimate: 15%; middle value at least 2.8-fold (0.45 log units) from the limit.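

This result shows that the place on the saturated chain carbon does not treat all aromatic groups alike. Naphthalen-1-yl and 4-phenylphenyl each carry 2 six-membered aromatic rings of carbon only and no hydrogen-bond donors or acceptors, yet the exchange gives an at least 2.3-fold higher number from compound 2 to compound 3 (0.37 log units; beyond the scatter), so an aromatic swap here can raise the number as well as lower it, as the earlier step did not show. Phenyl in place of fluoro on an aromatic carbon gives an at least 1.1-fold higher number from compound 1 to compound 3 (0.04 log units; that floor lies within the scatter), so this pair shows no firm gap, although the true gap may be larger. The reading for compound 3 in this assay is a limit and not a number, so each of these steps is only a floor: the limit of > 100000 nM in this assay, at which 1 of the 3 values shown sits.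

As far as these compounds go, how far the true value of compound 3 lies beyond that limit stays open, and so does the real size of both steps. Also open, from the compounds shown here alone, is how the number would respond to a naphthalen-2-yl group at this place, or to an amine or a carboxylic acid in place of the fluoro of compound 1.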